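Swapping Bromo for Methyl in a Cytotoxicity Series

The compounds below may be only part of what the source reports. "The series", "measured", "known", "first", "only" and "open" are said of these compounds alone.

Three measured compounds share a core and differ in the group on the outer six-membered ring. Compound 1 `OCc1cn(Cc2cccc(Br)c2)c2ccccc12` gives 32 nM in a functional assay on T29Kt1 cells (Homo sapiens) for cytotoxicity, read by sulforhodamine B assay, with a stated time of 3 days; on this read-out higher numbers stand for weaker inhibition and lower numbers for stronger inhibition. Compound 2 `OCc1cn(Cc2ccc(Br)cc2)c2ccccc12` has the same atoms joined differently; the difference between the two cores is not broken down here. In this assay compound 2 gives 390 nM. Compound 3 `Cc1cccc(Cn2cc(CO)c3ccccc32)c1` gives 1000 nM in this assay. From compound 1 to compound 3 the change is methyl in place of bromo on an aromatic carbon, which made the step of a 31-fold higher number from compound 1 to compound 3 (1.49 log units; beyond the scatter). Compound 4 `Cc1ccc(Cn2cc(CO)c3ccccc32)cc1` is not yet measured; from compound 2 it differs by methyl in place of bromo on an aromatic carbon. This is the same kind of change, but the place is not identical: meta to a large group in the first pair, para to a large group in the second. Because the earlier step of a 31-fold higher number from compound 1 to compound 3 (1.49 log units; beyond the scatter) was large, a weaker result is expected for compound 4, with an expected step of a 10-fold higher number from compound 2 to compound 4 (1.01 log units; beyond the scatter), judged somewhat smaller given the different place. Compound 4 is therefore expected to give about 4000 nM in this assay. Its estimated range runs from 1200 nM to 15000 nM.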

Compound 4, half-maximal inhibitory concentration: 150 nM
For compound 4 the middle estimate is 27-fold (1.43 log units) above the measured one, outside the stated range (below it).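

The new step, methyl in place of bromo on an aromatic carbon, gives a 2.6-fold lower number from compound 2 to compound 4 (0.41 log units; beyond the scatter) in this assay, so here the swap strengthens inhibition rather than weakening it. Set side by side, the two pairs disagree in both direction and size, so this change does not carry over from one core to the other: the same change on two cores in this assay, a 31-fold higher number (1.49 log units; beyond the scatter) from compound 1 to compound 3 and a 2.6-fold lower number (0.41 log units; beyond the scatter) from compound 2 to compound 4, 81-fold (1.91 log units) apart, beyond the scatter of two such steps. This does not show why the two pairs differ, whether the place para to a large group is what matters, or how the swap would behave on any other core in the series.

The compounds shown leave open how other groups in these places, such as chloro, methoxy or an amine, would compare with bromo and methyl. Going by these compounds, whether any of them would behave alike on both cores also remains open.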